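This account rests on a few compounds, and the source may have more. Where it says the series, first, only, none or still open, it means among the compounds named here.

Compound 1 `CNC(=O)c1cc(Oc2ccc(C(=O)/C=C/c3cccc([N+](=O)[O-])c3)cc2)ccn1` carries a 3-nitrophenyl on a double-bonded chain carbon bound to a double-bonded chain carbon; in a functional assay on A549 cells (Homo sapiens) for cytotoxicity, read by MTT assay, with a stated time of 72 h (a higher number here means a weaker inhibitor, a lower number a stronger inhibitor), compound 1 gives "not determined" (no result reported), so it stands without a number. Two close relatives anchor the series: compound 2 `CNC(=O)c1cc(Oc2ccc(C(=O)/C=C/c3cccc(Br)c3)cc2)ccn1` gives 9940 nM in this assay, and compound 3 `CNC(=O)c1cc(Oc2ccc(C(=O)/C=C/c3ccc(F)cc3)cc2)ccn1` gives 18600 nM. Among the measured compounds shown here, the single step between them, a 1.9-fold higher number from compound 2 to compound 3 (0.27 log units; within the scatter), shows that an exchange at that same place moved the number no further than the scatter. Compound 4 `CNC(=O)c1cc(Oc2ccc(C(=O)/C=C/c3ccc(OC)cc3)cc2)ccn1` differs from compound 1 by 4-methoxyphenyl in place of 3-nitrophenyl on a double-bonded chain carbon bound to a double-bonded chain carbon. For the measured compounds named here, no measured step matches this exchange, and compound 1 has no value to step from, so the expectation rests on compounds 2 and 3 alone. Compound 4 is therefore expected to land near them, estimated at 14000 nM with a range from 5000 nM to 40000 nM.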

Compound 4, half-maximal inhibitory concentration: > 50000 nM
Compound 4 was reported as a limit; the forecaster's own chance of this, stated with the estimate: 10%; middle value at least 3.5-fold (0.55 log units) from the limit.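

Compound 4 is reported only as a limit of the assay: the limit of > 50000 nM in this assay, at which 1 of the 4 values shown sits.

Unlike the earlier exchange, a 1.9-fold higher number from compound 2 to compound 3 (0.27 log units; within the scatter), changes at this place now move the number beyond the scatter in this assay: methoxy in place of fluoro gives an at least 2.6-fold higher number from compound 3 to compound 4 (0.42 log units; beyond the scatter), and 4-methoxyphenyl in place of 3-bromophenyl gives an at least 5.0-fold higher number from compound 2 to compound 4 (0.70 log units; beyond the scatter). The position is therefore not indifferent to the group it carries.

Compound 1 has no number, so steps from it cannot be read. On these data alone, whether an amine or a carboxylic acid in place of the methoxy would bring the number back toward those of compound 2 and compound 3 stays open.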